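This account rests on a few compounds, and the source may have more. Where it says the series, first, only, none or still open, it means among the compounds named here.

Compound 2 `CC(C)c1ccccc1OS(=O)(=O)c1ccc(NC(=O)CCCCl)cc1` and compound 1 `CCCC(=O)Nc1ccc(S(=O)(=O)Oc2ccccc2I)cc1` share a core in which an amide-bearing ring is linked through a sulfonate to a second aromatic ring. In a functional assay on M21 cells (Homo sapiens) for antiproliferative activity, read by sulforhodamine B assay, with a stated time of 48 h (on this read-out lower numbers stand for stronger inhibition and higher numbers for weaker inhibition), compound 1 gives 9000 nM, and compound 2 gives 5100 nM. Compound 2 sits at the low end of these two numbers, but the gap to compound 1 is within the scatter, so the two cannot be told apart on this read-out.

Compound 3 `O=C(CCCCl)Nc1ccc(S(=O)(=O)Oc2ccccc2I)cc1` has not yet been measured in this assay. Compound 3 differs from compound 2 in one place: iodo in place of isopropyl on an aromatic carbon. Among the compounds with values here, no measured pair shows this change on its own, so no step size is known for it; the expectation is a small step, not beyond the scatter, in either direction. On that basis compound 3 is expected to give about 7000 nM, in a range from 2500 nM to 20000 nM, a step of a 1.4-fold higher number from compound 2 to compound 3 (0.14 log units; within the scatter) that is expected to stay within the scatter.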

Compound 3, half-maximal inhibitory concentration: 7200 nM
Compound 3: middle estimate off by 1.0-fold (0.01 log units), on the low side, within the range that was stated.
By their numbers in this assay, from the lowest: compounds 2, 3 and 1 (each within the scatter of the next).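

In this assay, iodo in place of isopropyl on the aromatic carbon ortho to a large group gives a 1.4-fold higher number from compound 2 to compound 3 (0.15 log units; within the scatter), so at this position the two groups cannot be told apart, even though one has a single heavy atom and the other has three. On the other side of the molecule, chloro in place of hydrogen on a saturated chain carbon, three bonds along the chain from a carbonyl carbon, gives a 1.3-fold lower number from compound 1 to compound 3 (0.10 log units; within the scatter), so this change also has no readable effect on the number. Nothing available explains why either change leaves the read-out within the scatter.

The compounds shown leave open whether an amine or a carboxylic acid on that aromatic carbon would move the number beyond the scatter. They also leave open whether a longer chain on the amide would do so.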